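Lengthening the linker in a sigma-1 binding series

The source may hold more compounds than are shown below. What is called first, only, known or untested is meant among the compounds shown, and "the series" means these compounds.

Compound 1 `O=c1sc2ccccc2n1CCCN1CCCCCC1` is tested in an assay on cell membranes for displacement of a labelled ligand from Sigma non-opioid intracellular receptor 1 (Rattus norvegicus) (on this read-out higher numbers stand for weaker inhibition and lower numbers for stronger inhibition), and gives 4.1 nM. Compound 2 `CCC(=O)c1ccc2c(c1)sc(=O)n2CCN1CCCCCC1` carries a propanoyl group on the shared core and a shorter chain to the azepane; in this assay compound 2 gives 4.5 nM, a number that sits within the scatter of compound 1. Compound 3 `CCC(=O)c1ccc2c(c1)sc(=O)n2CCCN1CCCCCC1` differs from compound 2 by (azepan-1-yl)methyl in place of azepan-1-yl on a saturated chain carbon, two bonds along the chain from an aromatic nitrogen, which makes its chain match that of compound 1. No step beyond the scatter is expected from compound 2 to compound 3, a 1.3-fold lower number from compound 2 to compound 3 (0.11 log units; within the scatter). Compound 3 is estimated at 3.5 nM, with a range from 1.5 nM to 9 nM.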

Compound 3, inhibition constant: 3.7 nM
Compound 3: the middle estimate sits 1.1-fold (0.02 log units) below what was measured, within the range that was stated.
By their numbers in this assay, from the lowest: compounds 3, 1 and 2 (each within the scatter of the next).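

Replacing azepan-1-yl with (azepan-1-yl)methyl on a saturated chain carbon, two bonds along the chain from an aromatic nitrogen, gives a 1.2-fold lower number from compound 2 to compound 3 (0.09 log units; within the scatter) in this assay. Replacing hydrogen with propanoyl on an aromatic carbon gives a 1.1-fold lower number from compound 1 to compound 3 (0.04 log units; within the scatter), so with this chain the core tolerates the propanoyl group, and neither single change moves the number beyond the scatter. Nothing measured here explains how close these numbers lie.

Still open, from the compounds shown here alone, is how a longer chain or a piperidine in place of the azepane would read in this assay. Also open, going by these compounds, is whether a carboxylic acid in place of propanoyl would keep the number in this range.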